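A few compounds are considered here, and "the series" means these few. Any claim that something is new, unique, unknown or untested is made for them only; others in the source may bear on it.

Measured compounds:
compound 1 `Cn1cnc2c(N3CCCCC3)nc(-c3ccccc3O)nc21` — 20%
compound 2 `Oc1cccc(-c2nc(N3CCCCC3)c3nc[nH]c3n2)c1` — > 80%

Two compounds carry values in an assay on cells for displacement of a labelled ligand from adenosine receptor A3 (Homo sapiens), read by scintillation counting and radioligand binding, with a stated time of 180 min, tested at 10 uM; on this read-out higher numbers stand for more inhibition at the one concentration tested (going by the name of the read-out) and lower numbers for less inhibition. Compound 1 `Cn1cnc2c(N3CCCCC3)nc(-c3ccccc3O)nc21` gives 20% in this assay. For compound 2 `Oc1cccc(-c2nc(N3CCCCC3)c3nc[nH]c3n2)c1` the read-out in this assay is a limit, > 80%, not a number. Compound 2 thus stands at the limit of > 80% in this assay, at which 1 of the 2 values shown sits, and how far past it the true value lies is not known. Going by the values given here, compound 1 and compound 2 differ in two places at once, so their two values show only that one sits low and the other reaches the limit; no single step between them is drawn.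

Compound 3 `Cn1cnc2c(N3CCCCC3)nc(-c3cccc(O)c3)nc21` is not yet measured in this assay. It departs from compound 2 by methyl in place of hydrogen on an aromatic nitrogen. Among the compounds with values here, no step between measured compounds sizes this change on its own. Compound 1 also carries the methyl on the ring nitrogen and sits low, but it differs from compound 3 at the hydroxyl as well, so it is a pointer, not a measure. The expectation is a fall in this assay beyond the scatter, the step of a number at least 30 percentage points lower from compound 2 to compound 3 (beyond the scatter). Compound 3 is estimated at 50% in this assay, between 20% and 85%.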

Compound 3, a percentage reported as inhibition, at one concentration (the size of the read-out at that concentration, not a potency): 49.1%
For compound 3 the middle estimate is 0.9 percentage points above the measured one; the range from low to high includes it.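

Methyl in place of hydrogen on an aromatic nitrogen now has a size of its own in this assay, where the earlier pair could not separate it from the change at the hydroxyl: a number at least 30.9 percentage points lower from compound 2 to compound 3 (beyond the scatter) is the step read for this change alone. With the methyl present on both sides, 3-hydroxyphenyl in place of 2-hydroxyphenyl on an aromatic carbon is also sized, as a number 29.1 percentage points higher from compound 1 to compound 3 (beyond the scatter), so both single changes move the read-out beyond the scatter. The step from compound 2 is open at its far end, because the read-out of compound 2 is a limit and not a number: the limit of > 80% in this assay, at which 1 of the 3 values shown sits.

The compounds shown leave open whether an ethyl or a longer chain on that ring nitrogen would lower the read-out further than methyl, and whether a chain ending in an amine or a carboxylic acid would do the same. They also leave open how 2-hydroxyphenyl reads with hydrogen on the ring nitrogen, and what an amine in place of the hydroxyl would give.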